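Swapping an Acetyl Group for a Pyridine-Bearing Carbonyl

This account rests on a few compounds, and the source may have more. Where it says the series, first, only, none or still open, it means among the compounds named here.

Of the compounds shown here, two with closely related structures have been measured so far. In a functional assay on Ishikawa cells (Homo sapiens) for inhibition, read by MTT assay, with a stated time of 72 h, tested at 10 ug/mL (on this read-out higher numbers stand for more inhibition of growth at the one concentration tested and lower numbers for less inhibition of growth), compound 1 `C=C1[C@H](OC(C)=O)C[C@@H](OC(C)=O)C(C)(C)/C=C/[C@@H](C)C(=O)[C@@]2(OC(C)=O)C[C@@](C)(OC(C)=O)[C@H](OC(C)=O)[C@@H]2[C@H]1OC(C)=O` gives 29.4%. Compound 2 `C=C1[C@H](OCC(C)C)[C@@H](OC(C)=O)[C@@H](OC(C)=O)C(C)(C)/C=C/[C@@H](C)C(=O)[C@@]2(OC(C)=O)C[C@@](C)(OC(C)=O)[C@H](OC(C)=O)[C@@H]2[C@H]1OC(C)=O` gives 21.4% in this assay. These two values lie within the scatter of each other, so neither can be called the better of the pair, and both show only modest inhibition at the single concentration tested.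

Compound 3 `C=C1[C@H](OC(C)=O)C[C@@H](OC(=O)c2cccnc2)C(C)(C)/C=C/[C@@H](C)C(=O)[C@@]2(OC(C)=O)C[C@@](C)(OC(C)=O)[C@H](OC(C)=O)[C@@H]2[C@H]1OC(C)=O` keeps the core of compound 1 and changes one place: pyridin-3-yl stands in place of methyl on a carbonyl carbon, which turns an acetyl into a (pyridin-3-yl)carbonyl (pyridin-3-yl in place of methyl on a carbonyl carbon). This swap brings in an aromatic ring and a new hydrogen-bond acceptor. Going by the values given here, no pair of measured compounds differs in only one place, so the data offer no direct guide to the size of such a step. The safest expectation is therefore no change beyond the scatter, in either direction. The estimated step is a number 0.4 percentage points lower from compound 1 to compound 3 (within the scatter). For compound 3 the expected value is 29%, with an estimated range from 12% to 48%.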

Compound 3, percent growth inhibition at one concentration: 8.1%
Compound 3: the middle estimate sits 20.9 percentage points above what was measured; measured number below the stated range.
By their numbers in this assay, from the lowest: compound 3; then compounds 2 and 1 (each within the scatter of the next).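

Going by these compounds alone, compound 3 gives the first comparison here in which only one place changes, and it shows that what sits on this carbonyl carbon matters for growth inhibition. In this assay, putting pyridin-3-yl in place of methyl gives a modest step, a number 21.3 percentage points lower from compound 1 to compound 3 (beyond the scatter), which lies beyond the usual scatter, so this acetoxy group cannot be replaced by ((pyridin-3-yl)carbonyl)oxy without a cost in this read-out. Nothing available explains the drop, and no separate measurement on these compounds bears on it.

The compounds shown leave open whether the step comes from the aromatic ring as such, from its ring nitrogen or simply from a larger group, and a phenyl or an ethyl on the same carbonyl carbon would help to tell these apart. They also leave open how a free hydroxyl in place of this acetoxy group would compare, and whether the other acetoxy groups on the shared core respond to the same swap in the same way.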